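The compounds below may be only part of what the source reports. "The series", "measured", "known", "first", "only" and "open" are said of these compounds alone.

Working notes on the series. Among the compounds with values here, compound 1 `C=C1CCC[C@@H]2[C@@H](CC[C@@]3(C)CC[C@H]([C@H](C)C(=O)O)OO3)[C@H](C)CC[C@@]12C` is the one member with a numerical result: in a functional assay on 786-0 cells (Homo sapiens) for cytotoxicity, read by colony formation (a lower number here means a stronger inhibitor of growth, a higher number a weaker inhibitor of growth), compound 1 gives 500 nM. Within the data shown here, compound 2 `C=C1CCCC(C)(C)C1(O)CC/C(C)=C/CC[C@]1(C)CC[C@H]([C@@H](C)C(=O)OC)OO1` differs from compound 1 in much of its structure, and the two share no single-point step. In this assay compound 2 returns only a limit, > 5000 nM. Compound 2 therefore stands at the limit of > 5000 nM in this assay, at which 1 of the 2 values shown sits, and its true value is not known. Compound 3 `C=C1CCCC(C)(C)C1(O)CC/C(C)=C/CC[C@]1(C)CC[C@@H]([C@@H](C)C(=O)OC)OO1` is the next member to be tested. How compound 3 differs from compound 2: the two compounds have the same atoms and bonds; at least one stereo element is drawn with a configuration in one of them and without one in the other: 1 of 5 stereo elements differ; a stereocentre at a saturated ring carbon is drawn R in compound 2 and S in compound 3. Among the measured compounds shown here, no measured step between two compounds is available, so the expected size of the step in this assay is none beyond the scatter, in either direction. The step from compound 2 to compound 3 is therefore expected to be a step that the limit leaves unreadable from compound 2 to compound 3. For compound 3 in this assay the estimate is 6000 nM, expected to lie between 1500 nM and 20000 nM.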

Compound 3, concentration for 50% growth inhibition: > 5000 nM
Compound 3: only a limit was reported (the forecaster's own chance of this, stated with the estimate: 60%); the middle value does not contradict the limit.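

In this assay compound 3 returns only a limit, as compound 2 does, and no step can be read between the two. The compounds shown leave open whether the stereocentre at a saturated ring carbon, drawn R in compound 2 and S in compound 3, alters growth inhibition at all.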